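Methyl in place of trifluoromethyl: a small expected step

The source may report more compounds than this note shows. Statements on the series, on what has been measured and on what is new or still open speak of the compounds shown alone.

Of the compounds shown here, two that share one core have been measured so far in a functional assay on MCF7 cells (Homo sapiens) for inhibition, read by MTT assay; on this read-out higher numbers stand for weaker inhibition of growth and lower numbers for stronger inhibition of growth. There, compound 1 `COc1cc2oc(-c3cccc(NC(=O)c4ccc([N+](=O)[O-])cc4)c3)cc(=O)c2c(OC)c1OC` gives 20100 nM, and compound 2 `COc1cc2oc(-c3cccc(NC(=O)c4ccc(C(F)(F)F)cc4)c3)cc(=O)c2c(OC)c1OC` gives 10600 nM. These two values lie within the scatter of each other, so compound 2 cannot be separated from compound 1 on these numbers.

The next compound, compound 3 `COc1cc2oc(-c3cccc(NC(=O)c4ccc(C)cc4)c3)cc(=O)c2c(OC)c1OC`, has methyl in place of trifluoromethyl on an aromatic carbon, para to a large group: methyl in place of trifluoromethyl on an aromatic carbon. Within the data shown here, only one measured step bears on this change. It is a 1.9-fold lower number from compound 1 to compound 2 (0.28 log units; within the scatter), with trifluoromethyl in place of nitro on an aromatic carbon at that same place. Among the measured compounds shown here, this is a single step, and no measured compound carries methyl, so the evidence is thin and the range must stay wide. From that step, no change beyond the scatter is expected in this assay, and the estimated step is a 1.1-fold higher number from compound 2 to compound 3 (0.05 log units; within the scatter). For compound 3 the estimate is 12000 nM, with the value expected to fall from 5000 nM to 28000 nM.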

Compound 3, concentration for 50% growth inhibition: 8320 nM
Beside the measured number, compound 3's estimate is 1.4-fold (0.16 log units) above it; measured number inside the range.
By their numbers in this assay, from the lowest: compounds 3, 2 and 1 (each within the scatter of the next, the first and the last beyond it).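

In this assay, swapping trifluoromethyl for methyl on an aromatic carbon, para to a large group, gives a 1.3-fold lower number from compound 2 to compound 3 (0.11 log units; within the scatter) and so does not separate these two groups on these numbers. Methyl in place of nitro at the same place gives a 2.4-fold lower number from compound 1 to compound 3 (0.38 log units; beyond the scatter) and is a modest step, but it is the first one in this series to clear the usual scatter of repeat measurements, while compound 2 remains within the scatter of both compound 1 and compound 3. The three groups tried at this place therefore span only a narrow range, yet the two ends of that range can now be told apart, and no evidence is at hand to explain this difference.

The compounds shown leave open whether an amine, a carboxylic acid or a longer chain such as propyl at this place would stay within that narrow range or fall well outside it. They also leave open whether methyl in place of nitro would give a similar step on a different core, since all three compounds share one.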